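This account rests on a few compounds, and the source may have more. Where it says the series, first, only, none or still open, it means among the compounds named here.

Values in a functional assay on A549 cells (Homo sapiens) for antiproliferative activity, read by MTT assay, with a stated time of 72 h; a lower number here means a stronger inhibitor, a higher number a weaker inhibitor:
- compound 1 `CCCCc1cn(C[C@H](O)[C@H]2OC(=O)C(OCc3ccccc3)=C2OCc2ccccc2)nn1`: 28600 nM
- compound 2 `O=C1O[C@H]([C@@H](O)Cn2ccnn2)C(OCc2ccccc2)=C1OCc1ccccc1`: > 100000 nM, a limit of the assay and not a number

Compound 2 stands at the limit of > 100000 nM in this assay, at which 1 of the 2 values shown sits, so only a limit is known for it. Compound 3 `O=C1O[C@H]([C@@H](O)Cn2cc(CCO)nn2)C(OCc2ccccc2)=C1OCc1ccccc1` differs from it in one place: 2-hydroxyethyl in place of hydrogen on an aromatic carbon. In words, 2-hydroxyethyl takes the place of hydrogen on an aromatic carbon. For the measured compounds named here, the one measured step at this same place is an at least 3.4-fold higher number from compound 1 to compound 2 (0.54 log units; beyond the scatter). Read in reverse, it shows that butyl at this place gives a measurable value, so a group here may again bring the number down. However, 2-hydroxyethyl is a different group, and a single step is thin support. Going by the values given here, a smaller gain is therefore expected than the one seen for compound 1 at 28600 nM. The expected change is an at least 1.4-fold lower number from compound 2 to compound 3 (0.15 log units; that floor lies within the scatter), towards a lower number. For compound 3 the estimate is 70000 nM, with an expected range of 30000 nM to 150000 nM.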

Compound 3, half-maximal inhibitory concentration: > 100000 nM
Compound 3 gave a limit, no number (the forecaster's own chance of this, stated with the estimate: 50%); at least 1.4-fold (0.15 log units) between middle value and limit.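

In this assay, the end of the chain on this aromatic carbon turns out to matter: hydroxy in place of ethyl on a saturated chain carbon gives an at least 3.4-fold higher number from compound 1 to compound 3 (0.54 log units; beyond the scatter). A chain at this place therefore does not by itself give a measurable value, and of the two chains shown, only the butyl of compound 1 does. Compound 2 and compound 3 each stand at a limit of the assay rather than at a number, so the step between them cannot be read: the limit of > 100000 nM in this assay, at which 2 of the 3 values shown sit.

From the compounds shown here alone, compound 1 gives 28600 nM, and whether a longer chain such as hexyl would bring the number further down remains open. Going by these compounds, it is also open whether a chain ending in an amine or a carboxylic acid, rather than hydroxy, would give a measurable value.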